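The source may report more compounds than this note shows. Statements on the series, on what has been measured and on what is new or still open speak of the compounds shown alone.

Working notes on the series. Compound 1, `O=C(NC(=S)Nc1ccc(F)cc1)c1cn(-c2ccccc2)nc1-c1ccccc1`, is the starting point; in a functional assay on A549 cells (Homo sapiens) for inhibition, read by CCK-8 assay, with a stated time of 48 h (a lower number here means a stronger inhibitor, a higher number a weaker inhibitor), compound 1 gives 3500 nM. Compound 2, `Cc1ccc(NC(=S)NC(=O)c2cn(-c3ccccc3)nc2-c2ccccc2)cc1`, carries methyl in place of fluoro on an aromatic carbon; in this assay compound 2 gives 2800 nM. The step of a 1.3-fold lower number from compound 1 to compound 2 (0.10 log units; within the scatter) is within the scatter, so the two numbers cannot be ordered. Among the two numbers so far compound 1 holds the highest, with compound 2 as its only neighbour.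

Compound 3, `O=C(NC(=S)Nc1ccc(F)cc1)c1cn(-c2ccccc2)nc1-c1ccc(Cl)cc1`, differs from compound 1 by chloro in place of hydrogen on an aromatic carbon, on a six-membered aromatic ring of carbon only, para to a large group; cut one bond further out the change reads phenyl to 4-chlorophenyl. Among the measured compounds shown here, no measured step touches this change. For the measured compounds named here, the only step in hand, a 1.3-fold lower number from compound 1 to compound 2 (0.10 log units; within the scatter), concerns a different substituent exchange and is itself within the scatter, so the series gives no ground for a step beyond the scatter in this assay in either direction. Compound 3 is therefore expected to give 2600 nM, within 1000 nM to 7000 nM. The expected step of a 1.3-fold lower number from compound 1 to compound 3 (0.13 log units; within the scatter) is small.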

Compound 3, half-maximal inhibitory concentration: 3980 nM
Compound 3: middle estimate off by 1.5-fold (0.18 log units), on the low side; low and high end bracket the measured number.
By their numbers in this assay, from the lowest: compounds 2, 1 and 3 (each within the scatter of the next).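

The step of a 1.1-fold higher number from compound 1 to compound 3 (0.06 log units; within the scatter) in this assay lies within the scatter, so on this evidence, replacing hydrogen with chloro on this aromatic carbon, para to a large group, produces no readable change in the number. Among the compounds shown here, the earlier pair covered only the exchange of fluoro and methyl at another place, so this is the first reading at this position, and the single changes at both places now fall within the scatter for compounds 1, 2 and 3. No measurement on hand bears on why the phenyl to 4-chlorophenyl change behaves this way.

On these data alone, one substituent at one position is a narrow test, so it remains open whether an amine, a carboxylic acid or a longer chain in the place of the chloro would give a step beyond the scatter in this assay and thereby show that this position can affect the number at all. Also open, as far as these compounds go, is whether the same phenyl to 4-chlorophenyl change would read the same on the core of compound 2, which carries methyl rather than fluoro.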